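Benzyl Variation on the Shared Core: Growth Inhibition Notes

The compounds below may be only part of what the source reports. "The series", "measured", "known", "first", "only" and "open" are said of these compounds alone.

Compound 1 `Nc1cc(N)c2nc(-c3ccccc3)c(NCc3ccc(Cl)c(Cl)c3)nc2c1` gives the lower of the two numbered results in a functional assay on DU-145 cells (Homo sapiens) for inhibition, read by sulforhodamine B assay, with a stated time of 48 h (a higher number here means a weaker inhibitor of growth, a lower number a stronger inhibitor of growth), where compound 1 reads 33100 nM. Compound 2 `Nc1cc(N)c2nc(-c3ccccc3)c(Oc3ccc(F)cc3)nc2c1` reads 87100 nM in this assay, a gap beyond the usual scatter. Compound 3 `CCOC(=O)[C@H](CCC(=O)O)NC(=O)c1ccc(CNc2nc3cc(N)cc(N)c3nc2-c2ccccc2)cc1` reaches only a limit of the assay, < 100000 nM; this is the limit of < 100000 nM in this assay, at which 1 of the 3 values shown sits. Compound 4 `COc1ccc(CNc2nc3cc(N)cc(N)c3nc2-c2ccccc2)cc1` is not yet measured; it differs from compound 1 by 4-methoxyphenyl in place of 3,4-dichlorophenyl on a saturated chain carbon bound to a nitrogen on an aromatic ring. With no measured step of this kind among the compounds shown, no movement beyond the scatter is expected in this assay, though the sparse and weak numbers leave the range wide. Compound 4 is estimated at 40000 nM, within 15000 nM to 100000 nM. The expected step is a 1.2-fold higher number from compound 1 to compound 4 (0.08 log units; within the scatter).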

Compound 4, concentration for total growth inhibition: 57500 nM
Estimate against measurement, compound 4: 1.4-fold (0.16 log units) below; the range from low to high includes it.
By their numbers in this assay, from the lowest: compounds 1, 4 and 2 (each within the scatter of the next, the first and the last beyond it).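

Within the data shown here, putting 4-methoxyphenyl in place of 3,4-dichlorophenyl on a saturated chain carbon bound to a nitrogen on an aromatic ring gives a 1.7-fold higher number from compound 1 to compound 4 (0.24 log units; within the scatter) in this assay as the first one-place step. At this position, losing both chlorines and gaining a hydrogen-bond acceptor leaves compound 4 unresolved from compound 1. Compound 3 remains a limit of the assay, not a number: the limit of < 100000 nM in this assay, at which 1 of the 4 values shown sits.

Going by these compounds, whether an amine or a carboxylic acid on this benzyl ring would move the number beyond the scatter remains open. A longer chain in place of the benzyl link is equally unresolved.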